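Cytotoxicity notes on a small hydroxyamino amide series

The source may report more compounds than this note shows. Statements on the series, on what has been measured and on what is new or still open speak of the compounds shown alone.

Measured so far, in an ADME assay on Huh-7 cells (Homo sapiens) for cytotoxicity, read by a luciferase reporter and WST assay, with a stated time of 3 days; a lower number here means that less compound is tolerated, a higher number that more compound is tolerated:

Compound 1 `Cc1ccc(-c2cc(NO)c(C(=O)Nc3ccccc3)c(=O)o2)cc1` gives > 20000 nM, which is a limit of the assay and not a number.
Compound 2 `COc1ccc(-c2cc(NO)c(C(=O)Nc3ccccc3)c(=O)o2)cc1` gives 16200 nM.
Compound 3 `CNC(=O)c1c(NO)cc(-c2ccc(C)cc2)oc1=O` gives > 20000 nM, again a limit of the assay rather than a number.

Two of the three values sit at the limit of > 20000 nM in this assay, at which 2 of the 3 values shown sit, so the series is only thinly resolved. The one change that is read as a number is methoxy in place of methyl on an aromatic carbon, which gives an at least 1.2-fold lower number from compound 1 to compound 2 (0.09 log units; that floor lies within the scatter); that floor is within the scatter, so no real movement is shown. The change methyl in place of phenyl on an amide-type nitrogen gives a step that the two limits leave unreadable from compound 1 to compound 3, as both ends are limits.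

Compound 4 `CNC(=O)c1c(NO)cc(-c2ccc(OC)cc2)oc1=O` is not yet measured. It carries the same change that separates compound 1 from compound 2, namely (methoxy in place of methyl on an aromatic carbon), and the place lines of the two changes agree word for word, so it is the same change, made here on the core of compound 3; the two cores differ by methyl in place of phenyl on an amide-type nitrogen.

For compound 4 a step of an at least 1.1-fold lower number from compound 3 to compound 4 (0.07 log units; that floor lies within the scatter) in this assay is expected, resting on the step from compound 1 to compound 2 being at least as small as its floor within the scatter and on compound 3 giving only a limit. Compound 4 is therefore estimated at 17000 nM, with a range from 9000 nM to 40000 nM, and a fair chance that this assay again reports only a limit.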

Compound 4, half-maximal cytotoxic concentration: > 20000 nM
Compound 4 ended at the assay's limit; the forecaster's own chance of this, stated with the estimate: 55%; middle value at least 1.1-fold (0.07 log units) from the limit.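

In this assay compound 4 gives > 20000 nM, which is a limit of the assay and not a number, so methoxy in place of methyl on an aromatic carbon cannot be read as a step on the core of compound 3, where both ends are limits. The one new step that can be read is methyl in place of phenyl on an amide-type nitrogen, at an at least 1.2-fold higher number from compound 2 to compound 4 (0.09 log units; that floor lies within the scatter), so no real movement is shown for that change either. This is consistent with the methoxy change behaving alike on the two cores, in that neither core shows a real movement, but it does not show that the change carries over, as its size is not resolved on either core and the series remains bunched at one end of the scale: the limit of > 20000 nM in this assay, at which 3 of the 4 values shown sit.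

The compounds shown leave open whether any change to the shared core gives a value clearly away from that limit on both cores, since only methyl and methoxy are compared on the aromatic ring and only methyl and phenyl on the amide nitrogen. An amine or a carboxylic acid in place of the methoxy, or a longer chain on the amide nitrogen, lies outside what these values can speak to.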